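Propoxy for isobutylamino: tolerance outlook on the shared core

The source may report more compounds than this note shows. Statements on the series, on what has been measured and on what is new or still open speak of the compounds shown alone.

Compound 3 `CC(C)CNc1nc(N)nc2c1ncn2/C=C1/CC1(CO)CO` carries an isobutylamino group on the shared core. In an ADME assay on HFF cells (Homo sapiens) for cytotoxicity, with a stated time of 8 days (a higher number here means that more compound is tolerated, a lower number that less compound is tolerated), compound 3 gives only a limit, > 300000 nM. Compound 1 `Nc1nc(NC2CC2)c2ncn(/C=C3/CC3(CO)CO)c2n1` likewise gives a limit in this assay, > 300000 nM. Compound 2 `CCCNc1nc(N)nc2c1ncn2/C=C1/CC1(CO)CO` also gives a limit in this assay, > 300000 nM. All three values sit at the same limit (the limit of > 300000 nM in this assay, at which 3 of the 3 values shown sit), so the steps a step that the two limits leave unreadable from compound 1 to compound 2, a step that the two limits leave unreadable from compound 1 to compound 3 and a step that the two limits leave unreadable from compound 2 to compound 3 cannot be read. Compound 4 `CCCOc1nc(N)nc2c1ncn2/C=C1/CC1(CO)CO` differs from compound 3 by propoxy in place of isobutylamino on an aromatic carbon. Among the measured compounds shown here, no measured step bears on this change with a readable size; the cyclopropyl, propyl and isobutyl variants all stayed at the limit. Compound 4 is therefore expected to stay at the limit as well, with a step that the limit leaves unreadable from compound 3 to compound 4 not beyond the scatter. The estimate for compound 4 is 400000 nM, between 150000 nM and 1000000 nM.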

Compound 4, half-maximal cytotoxic concentration: > 300000 nM
Compound 4: no number, only a limit; the forecaster's own chance of this, stated with the estimate: 85%; the middle value does not contradict the limit.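

In this assay compound 4 gives only a limit, so its steps from compound 1, compound 2 and compound 3 cannot be read: the limit of > 300000 nM in this assay, at which 4 of the 4 values shown sit.

The compounds shown leave open how much more compound is tolerated past this limit, and whether any change on the shared core lowers tolerance.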